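Pentylsulfonyl hydrazide extension of the isoleucyl series

The source may hold more compounds than are shown below. What is called first, only, known or untested is meant among the compounds shown, and "the series" means these compounds.

Values in an assay on HEK293 cells for displacement of a labelled ligand from Type-2 angiotensin II receptor (Homo sapiens) (on this read-out lower numbers stand for stronger inhibition and higher numbers for weaker inhibition), for the compounds measured so far:
- compound 1 `CCCCS(=O)(=O)NNC(=O)[C@@H](NC(=O)c1cccc(Cn2ccnc2)c1)[C@@H](C)CC`: > 100000 nM, a limit of the assay, not a number
- compound 2 `CC[C@H](C)[C@H](NC(=O)c1cccc(Cn2ccnc2)c1)C(=O)NNS(=O)(=O)c1ccc(C)cc1`: 29000 nM
- compound 3 `CC[C@H](C)[C@H](NC(=O)c1cccc(Cn2ccnc2)c1)C(=O)NC#N`: "not determined" (no result reported)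

Compound 3 stands without a number; no result was obtained for it, so it gives no anchor of its own. Of the values shown, (the limit of > 100000 nM in this assay, at which 1 of the 3 values shown sits), and that entry belongs to compound 1 alone.

Compound 4 `CCCCCS(=O)(=O)NNC(=O)[C@@H](NC(=O)c1cccc(Cn2ccnc2)c1)[C@@H](C)CC` differs from compound 3 by (pentylsulfonyl)amino in place of cyano on an amide-type nitrogen. Among the measured compounds shown here, the only measured step, an at least 3.4-fold lower number from compound 1 to compound 2 (0.53 log units; beyond the scatter), concerns the group on the sulfonyl sulfur, not the change from compound 3 to compound 4, so it bears on compound 4 only indirectly: it shows that compound 1, which carries the butyl chain, sits at the limit, while compound 2 with the 4-methylphenyl group reaches a measurable number. Compound 4 carries a pentyl chain on the same sulfonyl sulfur, closer to compound 1 than to compound 2, so no step beyond the scatter from the position of compound 1 is expected, and a result at or near the limit is the likely outcome.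

Compound 4 is therefore estimated at 100000 nM in this assay, with a range from 30000 nM to 300000 nM.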

Compound 4, inhibition constant: > 100000 nM
Compound 4: only a limit was reported (the forecaster's own chance of this, stated with the estimate: 60%); the middle value sits exactly at the limit.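

In this assay, compound 4 gives > 100000 nM, which is a limit of the assay and not a number. Pentyl in place of 4-methylphenyl on the sulfonyl sulfur gives an at least 3.4-fold higher number from compound 2 to compound 4 (0.53 log units; beyond the scatter), so among the sulfonyl hydrazides shown, both alkyl chains, butyl in compound 1 and pentyl in compound 4, lack a measurable number, and compound 2 alone has one, with no compound shown going against this. The step between compound 1 and compound 4 cannot be read, so the added chain carbon has no visible size of effect, because both compounds rest at the same limit: the limit of > 100000 nM in this assay, at which 2 of the 4 values shown sit.

On these data alone, whether the measurable number of compound 2 depends on the 4-methylphenyl group itself, or would also be reached with phenyl, 4-chlorophenyl or benzyl on the sulfonyl sulfur, remains open. Also open, as far as these compounds go, is whether a shorter chain such as methyl or ethyl on that sulfur would give a number, or whether a longer chain such as octyl would stay at the limit.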